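This account rests on a few compounds, and the source may have more. Where it says the series, first, only, none or still open, it means among the compounds named here.

Measured so far:
- compound 1, `CCCCCCCC/C=C/CCCCCCCC(=O)O[C@H]1[C@H](O)[C@H](n2ccc(N)nc2=O)O[C@@H]1CO`: 0.05 ug/mL
- compound 2, `CCCCCCCC(=O)O[C@H]1[C@H](O)[C@H](n2ccc(N)nc2=O)O[C@@H]1CO`: 0.1 ug/mL
- compound 3, `CCCCCCCCCCCCCC(=O)OC[C@H]1O[C@@H](n2ccc(N)nc2=O)[C@@H](O)[C@@H]1OC(=O)CCCCCCCCCCCCC`: 1.4 ug/mL

All values come from a functional assay on HeLa cells (Homo sapiens) for cytotoxicity, read by cell counting, with a stated time of 48 h; a higher number here means that more compound is needed for the effect, a lower number that less compound is needed. Going by the values given here, compound 1 sits at the low end of the three numbers: compound 2 lies within the scatter of it, while compound 3, the only compound in the set carrying two ester chains, lies well beyond it.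

The next compound is compound 4, `CCCCCCCCCC(=O)O[C@H]1[C@H](O)[C@H](n2ccc(N)nc2=O)O[C@@H]1CO`, which keeps the shared core of compound 1 and changes only the ester chain: a group of 2 heavy atoms (2 carbon; no ring) in place of a group of 10 heavy atoms (10 carbon; no ring), on a saturated chain carbon, seven bonds along the chain from a carbonyl carbon. Among the compounds with values here, the one measured step that bears on this is the shortening of the same chain from compound 1 to compound 2, a 2.0-fold higher number from compound 1 to compound 2 (0.30 log units; within the scatter). Compound 4 carries a chain of length between those of compound 1 and compound 2, so no step beyond the scatter is expected from compound 1; the expected step is a 1.4-fold higher number from compound 1 to compound 4 (0.15 log units; within the scatter). Compound 4 is therefore estimated at 0.07 ug/mL in this assay, within a range of 0.03 ug/mL to 0.15 ug/mL.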

Compound 4, concentration for half-maximal effect: 0.09 ug/mL
For compound 4 the middle estimate is 1.3-fold (0.11 log units) below the measured one; the measured number falls inside the stated range.
By their numbers in this assay, from the lowest: compounds 1, 4 and 2 (each within the scatter of the next); then compound 3.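

In this assay, the ester chain on the shared core now gives two further steps, both within the scatter: a 1.8-fold higher number from compound 1 to compound 4 (0.26 log units; within the scatter) and a 1.1-fold lower number from compound 2 to compound 4 (0.05 log units; within the scatter). The three single-chain compounds 1, 2 and 4 therefore show no readable dependence on the group on the saturated chain carbon, seven bonds along the chain from a carbonyl carbon, whether that group is hydrogen, ethyl or the group of compound 1 with its double bond. No measurement on hand accounts for this flat result.

Still open, from the compounds shown here alone, is whether a much shorter chain, such as an acetyl ester, or a chain ending in an amine or a carboxylic acid would stay within the same scatter. Also open, going by these compounds, is whether a fully saturated chain as long as that of compound 1 would match it, since the double bond and the extra chain carbons leave together in the step to compound 4.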